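Aryl substituent swaps on the fused core, hydroxamate series

The source may hold more compounds than are shown below. What is called first, only, known or untested is meant among the compounds shown, and "the series" means these compounds.

Measured so far:
- compound 1 `O=C(/C=C/c1ccc(CN2C(=O)/C(=C3\Nc4ccccc4\C3=N/O)c3cccc(Cl)c32)cc1)NO`; in a functional assay on PC-3 cells (Homo sapiens) for cytotoxicity, read by colorimetric assay (on this read-out higher numbers stand for weaker inhibition and lower numbers for stronger inhibition), compound 1 gives 90 nM
- compound 2 `O=C(/C=C/c1ccc(CN2C(=O)/C(=C3\Nc4ccccc4\C3=N/O)c3cc(Cl)ccc32)cc1)NO`; compound 2 gives 60 nM
- compound 3 `Cc1ccc2c(c1)/C(=C1/Nc3ccccc3/C1=N\O)C(=O)N2Cc1ccc(/C=C/C(=O)NO)cc1`; compound 3 gives 60 nM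

Compound 3 stands level with compound 2 at the digits shown, and compound 1 lies within the scatter of both. Within the data shown here, the one measured step at the position in question is no change at the digits printed from compound 2 to compound 3 (within the scatter).

Compound 4 `COc1ccc2c(c1)/C(=C1/Nc3ccccc3/C1=N\O)C(=O)N2Cc1ccc(/C=C/C(=O)NO)cc1` differs from compound 3 by methoxy in place of methyl on an aromatic carbon. Among the measured compounds shown here, the only step bearing on it is the chloro-to-methyl swap at the same place, which left the number unchanged; no step involving methoxy exists among the measured compounds. The step of a 1.2-fold higher number from compound 3 to compound 4 (0.07 log units; within the scatter) is therefore expected to stay within the scatter. Compound 4 is estimated at 70 nM, in the range 30 nM to 160 nM.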

Compound 4, half-maximal inhibitory concentration: 30 nM
Compound 4: the middle estimate sits 2.3-fold (0.37 log units) above what was measured; low and high end bracket the measured number.
By their numbers in this assay, from the lowest: compounds 4, 2, 3 and 1 (each within the scatter of the next, the first and the last beyond it).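

In this assay methoxy on this aromatic carbon gives a 2.0-fold lower number from compound 3 to compound 4 (0.30 log units; within the scatter) and a 2.0-fold lower number from compound 2 to compound 4 (0.30 log units; within the scatter) in the second comparison, so neither step leaves the scatter. Among these compounds, the position therefore accepts methoxy, with its oxygen and hydrogen-bond acceptor, alongside methyl and chloro, with no step among the three groups beyond the scatter. No measurement available here bears on the reason for these numbers.

As far as these compounds go, whether an amine, a carboxylic acid or the longer ethoxy on this carbon would also stay within the scatter remains open. Also open, from the compounds shown here alone, is how methoxy would fare at the chloro-bearing carbon of compound 1.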